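Series notes: aryl groups on the amide-type nitrogen

This account rests on a few compounds, and the source may have more. Where it says the series, first, only, none or still open, it means among the compounds named here.

Measured so far:
compound 1 `NC(=S)N/N=C/c1ccc2ccccc2n1` — > 100000 nM
compound 2 `COc1ccc(C)cc1NC(=S)N/N=C/c1ccc2ccccc2n1` — > 100000 nM

In a functional assay on HL-60 cells (Homo sapiens) for antiproliferative activity, read by sulforhodamine B assay, with a stated time of 72 h (a higher number here means a weaker inhibitor, a lower number a stronger inhibitor), compound 1 gives > 100000 nM, which is a limit of the assay and not a number. Compound 2 likewise gives only a limit, > 100000 nM. Going by the values given here, both readings therefore sit at the limit of > 100000 nM in this assay, at which 2 of the 2 values shown sit, so compound 1 stands at the top of what the assay can report, and the one further value shown stands at the same place; no true number is available for either.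

Compound 3 `Fc1ccccc1NC(=S)N/N=C/c1ccc2ccccc2n1` differs from compound 1 by 2-fluorophenyl in place of hydrogen on an amide-type nitrogen. Among the compounds with values here, no step between measured compounds is available to calibrate this change, but compound 2 already carries an aryl group on the same nitrogen and remains at the limit. The expected step from compound 1 to compound 3 is therefore none beyond the usual scatter, with the estimate meaning a step that the limit leaves unreadable from compound 1 to compound 3. Compound 3 is expected to give about 150000 nM, in a range from 40000 nM to 600000 nM, most likely reported again only as a limit.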

Compound 3, half-maximal inhibitory concentration: > 100000 nM
Compound 3: only a limit was reported; the forecaster's own chance of this, stated with the estimate: 80%; the middle value does not contradict the limit.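

In this assay compound 3 gives > 100000 nM as a limit of the assay and not a number. No step can be read from compound 1 to compound 3, because both stand at the same limit: the limit of > 100000 nM in this assay, at which 3 of the 3 values shown sit.

The compounds shown leave open whether any aryl group on this amide-type nitrogen can change antiproliferative activity in this series.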